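Urea Side Chain Tested Against a Cytotoxicity Read-out

A few compounds are considered here, and "the series" means these few. Any claim that something is new, unique, unknown or untested is made for them only; others in the source may bear on it.

Of the compounds shown here, three built on one shared core have been tested in a functional assay on MT4 cells (Homo sapiens); on this read-out lower numbers stand for higher toxicity in this test and higher numbers for lower toxicity in this test. Compound 1 `Cc1cn([C@@H]2O[C@H](CO[Si](C)(C)C(C)(C)C)[C@@]3(OS(=O)(=O)C=C3NC(=O)c3ccccc3)[C@H]2O[Si](C)(C)C(C)(C)C)c(=O)n(C)c1=O` gives 4900 nM. Compound 2 `COC(=O)C(=O)CNC1=CS(=O)(=O)O[C@@]12[C@@H](CO[Si](C)(C)C(C)(C)C)O[C@@H](n1cc(C)c(=O)n(C)c1=O)[C@@H]2O[Si](C)(C)C(C)(C)C` gives 10300 nM, and compound 3 `COC(=O)CC(=O)NC1=CS(=O)(=O)O[C@@]12[C@@H](CO[Si](C)(C)C(C)(C)C)O[C@@H](n1cc(C)c(=O)n(C)c1=O)[C@@H]2O[Si](C)(C)C(C)(C)C` gives 11900 nM. Among these three numbers compound 2 holds the second highest; compound 3 sits nearest, inside the usual scatter, while compound 1 stands furthest away, separated by a 2.1-fold higher number from compound 1 to compound 2 (0.32 log units; beyond the scatter).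

Compound 4 `CCOC(=O)CNC(=O)NC1=CS(=O)(=O)O[C@@]12[C@@H](CO[Si](C)(C)C(C)(C)C)O[C@@H](n1cc(C)c(=O)n(C)c1=O)[C@@H]2O[Si](C)(C)C(C)(C)C` has not yet been measured. It differs from compound 2 in a single spot: ((ethoxycarbonyl)methyl)carbamoyl in place of ((methoxycarbonyl)carbonyl)methyl on an amine nitrogen. The amine nitrogen keeps its bond to the double-bonded ring carbon of the core; only the chain hanging from it is exchanged.

Two measured steps speak to this kind of change. Replacing the benzoyl group of compound 1 gave a 2.1-fold higher number from compound 1 to compound 2 (0.32 log units; beyond the scatter), a modest shift, and swapping one ester-bearing chain for another gave a 1.2-fold higher number from compound 2 to compound 3 (0.06 log units; within the scatter), which stays within the scatter. Chains of similar size on this nitrogen have so far moved the number little, so for compound 4 a step of a 1.2-fold higher number from compound 2 to compound 4 (0.07 log units; within the scatter) is expected, hardly beyond the scatter. Compound 4 is therefore estimated at 12000 nM, with a range from 6000 nM to 25000 nM.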

Compound 4, half-maximal cytotoxic concentration: 3780 nM
For compound 4 the middle estimate is 3.2-fold (0.50 log units) above the measured one; measured number below the stated range.
By their numbers in this assay, from the lowest: compounds 4 and 1 (each within the scatter of the next); then compounds 2 and 3 (each within the scatter of the next).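

This position is less forgiving than compounds 2 and 3 suggested: in this assay, the ((ethoxycarbonyl)methyl)carbamoyl chain gives a clear drop (a 2.7-fold lower number from compound 2 to compound 4 (0.44 log units; beyond the scatter)), and the other ester-bearing chain shows a similar gap (a 3.1-fold lower number from compound 3 to compound 4 (0.50 log units; beyond the scatter)). Chains carrying an ester on this amine nitrogen therefore do not all read alike, since the step between compounds 2 and 3 stayed within the scatter while both steps to compound 4 lie beyond it. The new chain also leaves the number level with that of the benzoyl compound (a 1.3-fold lower number from compound 1 to compound 4 (0.11 log units; within the scatter)), so the aromatic benzoyl group and this open chain cannot be told apart on this read-out, and nothing available explains the shift.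

Compound 4 differs from compounds 2 and 3 by both an added nitrogen in the chain and an ethyl rather than a methyl ester, so the compounds shown cannot assign the drop to either feature. The same chain ending in a methyl ester or a carboxylic acid, or a longer chain on this nitrogen, would help separate these features.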